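The source may report more compounds than this note shows. Statements on the series, on what has been measured and on what is new or still open speak of the compounds shown alone.

Measured in a functional assay on SW-620 cells (Homo sapiens) for cytotoxicity, read by MTT assay, with a stated time of 72 h; a lower number here means a stronger inhibitor, a higher number a weaker inhibitor:
compound 1, `COc1cccc(/C=C2\CCC/C(=C\c3cccc(Cl)c3)C2=O)c1OC`: 9100 nM
compound 2, `COc1cccc(/C=C2\CCC/C(=C\c3ccc(Cl)cc3)C2=O)c1OC`: 11100 nM
compound 3, `COc1ccc(/C=C2\CCC/C(=C\c3cccc(Cl)c3)C2=O)cc1OC`: 5100 nM

Compounds 1 and 2 share one core; compound 3 and the unmeasured compound 4, `COc1ccc(/C=C2\CCC/C(=C\c3ccc(Cl)cc3)C2=O)cc1OC`, share another. The difference between the two cores is not broken down here. Within the first pair the change is 4-chlorophenyl in place of 3-chlorophenyl on a double-bonded chain carbon bound to a double-bonded ring carbon; in this assay it gave a 1.2-fold higher number from compound 1 to compound 2 (0.09 log units; within the scatter). The same change, (4-chlorophenyl in place of 3-chlorophenyl on a double-bonded chain carbon bound to a double-bonded ring carbon), leads from compound 3 to compound 4. Compound 3 and compound 1 lie within the scatter of each other in this assay; compound 3 does give a lower number than compound 2, and that gap is beyond the scatter.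

Going by the values given here, for compound 4 the only guide is the step seen once in the first pair. Because a 1.2-fold higher number from compound 1 to compound 2 (0.09 log units; within the scatter) is the only size this change has shown so far, and that size is within the scatter, compound 4 is expected to land close to compound 3. The expected step is a 1.2-fold higher number from compound 3 to compound 4 (0.08 log units; within the scatter). Compound 4 is estimated at 6100 nM, with a likely range from 3500 nM to 11000 nM.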

Compound 4, half-maximal inhibitory concentration: 5900 nM
Estimate against measurement, compound 4: 1.0-fold (0.01 log units) above; the range from low to high includes it.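

In this assay, 4-chlorophenyl in place of 3-chlorophenyl gives a 1.2-fold higher number from compound 3 to compound 4 (0.06 log units; within the scatter), so on this second core the change again stays within the scatter. Set beside the first core, the two steps do not differ: the same change on two cores in this assay, a 1.2-fold higher number (0.09 log units; within the scatter) from compound 1 to compound 2 and a 1.2-fold higher number (0.06 log units; within the scatter) from compound 3 to compound 4, 1.1-fold (0.02 log units) apart, within the scatter of two such steps. This shows that, on these two cores, the change carries over as a step too small to read, but it does not rank 3-chlorophenyl against 4-chlorophenyl, and it does not show that a step of larger size would carry over in the same way or that the result holds on any other core.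

The compounds shown leave open whether a different group on the double-bonded chain carbon, such as a phenyl ring bearing an amine or a carboxylic acid in place of the chlorophenyl, would move the number beyond the scatter. They also leave open how the two cores compare when taken on their own, as that difference is not broken down here.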